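This account rests on a few compounds, and the source may have more. Where it says the series, first, only, none or still open, it means among the compounds named here.

Measured in a functional assay on HepG2 cells (Homo sapiens) for antiproliferative activity, read by MTT assay, with a stated time of 72 h; on this read-out higher numbers stand for weaker inhibition and lower numbers for stronger inhibition:
- Compound 1 `COc1ccc(N2C(=O)COc3ccc(-c4cnc(Cl)c(NS(=O)(=O)c5ccc(F)cc5)c4)cc32)cc1`: > 40000 nM, a limit and not a number
- Compound 2 `CC(C)N1C(=O)COc2ccc(-c3cnc(Cl)c(NS(=O)(=O)c4ccc(F)cc4)c3)cc21`: 21500 nM
- Compound 3 `O=C1COc2ccc(-c3cnc(Cl)c(NS(=O)(=O)c4ccc(F)cc4)c3)cc2N1c1ccc(Cl)cc1`: 33900 nM

Only compound 2 and compound 3 have true numbers, and these two lie within the scatter of each other, as a 1.6-fold higher number from compound 2 to compound 3 (0.20 log units; within the scatter) shows. Compound 3 therefore stands level with compound 2 on the data available.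

The next compound is compound 4 `O=C1COc2ccc(-c3cnc(Cl)c(NS(=O)(=O)c4ccc(F)cc4)c3)cc2N1c1ccccc1`, which differs from compound 3 in one place: hydrogen in place of chloro on an aromatic carbon. In words, this is hydrogen in place of chloro on an aromatic carbon, para to a large group, so 4-chlorophenyl becomes phenyl.

The closest measured change is on that same aromatic carbon, chloro in place of methoxy: an at least 1.1-fold lower number from compound 1 to compound 3 (0.07 log units; that floor lies within the scatter). As far as these compounds go, this is only a floor, so its true size stays open. Larger swaps on the amide-type nitrogen in a ring also stayed within the scatter: an at least 1.8-fold lower number from compound 1 to compound 2 (0.26 log units; that floor lies within the scatter). For the measured compounds named here, no compound with plain phenyl has a value yet. On these steps, no change beyond the scatter is expected in this assay.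

The estimated step is a 1.1-fold lower number from compound 3 to compound 4 (0.05 log units; within the scatter). A result reported only as a limit, (the limit of > 40000 nM in this assay, at which 1 of the 3 values shown sits), is also possible. The expected value for compound 4 is 30000 nM, with an estimated range from 15000 nM to 60000 nM.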

Compound 4, half-maximal inhibitory concentration: 35700 nM
Estimate against measurement, compound 4: 1.2-fold (0.08 log units) below; low and high end bracket the measured number.
By their numbers in this assay, from the lowest: compounds 2, 3 and 4 (each within the scatter of the next). At a limit, above all of these: compound 1.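

In this assay, the chloro on this aromatic carbon, para to a large group, can give way to hydrogen with no readable effect, a 1.1-fold higher number from compound 3 to compound 4 (0.02 log units; within the scatter), and plain phenyl on the amide-type nitrogen in a ring stands level with isopropyl, a 1.7-fold higher number from compound 2 to compound 4 (0.22 log units; within the scatter). For the compounds shown here, the earlier compounds had no hydrogen at this carbon, so this is the first sign that the chloro itself adds nothing that can be told from the scatter here, though this rests on a single pair. The comparison with methoxy gives only a floor, an at least 1.1-fold lower number from compound 1 to compound 4 (0.04 log units; that floor lies within the scatter), so compound 1 could lie much further from compound 4 than that floor says, and compound 1 itself remains a limit and not a number: the limit of > 40000 nM in this assay, at which 1 of the 4 values shown sits.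

The compounds shown leave open whether a different kind of group on this aromatic carbon, such as an amine or a carboxylic acid, would carry the number beyond the scatter. They also leave open whether a small chain such as ethyl on the amide-type nitrogen in a ring would behave like isopropyl or phenyl.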